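The compounds below may be only part of what the source reports. "The series", "measured", "known", "first", "only" and "open" are said of these compounds alone.

Measured in a functional assay on NCI-H460 cells (Homo sapiens) for antiproliferative activity, with a stated time of 72 h; a higher number here means a weaker inhibitor, a lower number a stronger inhibitor:
Compound 1, `C=CC[C@H]1C[C@]2([C@@H](C)Cc3ccc(OC)c(OC)c3)OCOC2=CC1=O`, gives 260 nM.
Compound 2, `C=CC[C@H]1C[C@]2([C@@H](C)Cc3cnc(OC)cc3F)OCOC2=CC1=O`, gives only a limit of the assay, > 20000 nM.
Compound 3, `C=CC[C@H]1C[C@]2([C@@H](C)Cc3cc(OC)c(OC)cc3F)OCOC2=CC1=O`, gives 120 nM.

Compound 3 holds the lowest of the two numbers actually measured in this assay. Its nearest neighbour is compound 1, and the step of a 2.2-fold lower number from compound 1 to compound 3 (0.34 log units; beyond the scatter) is modest but beyond the usual scatter. That step is the only measured one with a single change, and it concerns a fluoro in place of hydrogen on the aromatic ring.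

Compound 4, `C=CC[C@H]1C[C@]2([C@@H](C)Cc3cc(O)c(OC)cc3F)OCOC2=CC1=O`, differs from compound 3 by hydrogen in place of methyl on an oxygen on an aromatic ring; one bond further out, this reads as methoxy to hydroxy. For the measured compounds named here, none of the measured steps touches this oxygen, so the fluoro step offers no direct guide to the direction or size of the change in this assay. With nothing to anchor it, the expected step of a 2.1-fold higher number from compound 3 to compound 4 (0.32 log units; beyond the scatter) is set close to no change, leaning slightly toward a higher number, with a wide range. Compound 4 is therefore expected to give about 250 nM, between 80 nM and 900 nM.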

Compound 4, half-maximal inhibitory concentration: 33 nM
Beside the measured number, compound 4's estimate is 7.6-fold (0.88 log units) above it, outside the stated range (below it).
By their numbers in this assay, from the lowest: compound 4; then compound 3; then compound 1. At a limit, above all of these: compound 2.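

In this assay, the methyl on this oxygen is not needed for activity: the step of a 3.6-fold lower number from compound 3 to compound 4 (0.56 log units; beyond the scatter) shows that the hydroxy form gives the lower number. This is the first change shown at this oxygen, and it shows that the methoxy group can be altered here without a loss in this assay. Added to the fluoro step a 2.2-fold lower number from compound 1 to compound 3 (0.34 log units; beyond the scatter) on the same kind of aromatic ring, it gives a second single change that lowers the number.

No measurement shown explains why removing the methyl lowers the number. Going by these compounds, it also remains open whether a longer chain on this oxygen, as in an ethoxy group, or an amine in place of the hydroxy, would keep this activity.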